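The compounds below may be only part of what the source reports. "The series", "measured", "known", "first", "only" and "open" are said of these compounds alone.

Of the compounds shown here, two sharing one core have been measured in a functional assay on LOX IMVI cells (Homo sapiens) for inhibition, read by sulforhodamine B assay, with a stated time of 48 h, tested at 10 uM; on this read-out higher numbers stand for more inhibition at the one concentration tested (going by the name of the read-out) and lower numbers for less inhibition. Compound 1, `c1ccc(-c2cn3ccnc3c(-c3ccc4ncn(C5CCCCC5)c4c3)n2)cc1`, gives 39.6% in this assay. Compound 2, `CCc1ccc(-c2cn3ccnc3c(-c3ccc4ncn(Cc5ccccc5)c4c3)n2)cc1`, gives 50.2% in this assay, the higher of the two numbers; the gap between compound 2 and compound 1 lies beyond the usual scatter, so compound 2 shows the greater inhibition at the single concentration tested.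

Compound 3, `O=Cc1ccc(-c2cn3ccnc3c(-c3ccc4ncn(Cc5ccccc5)c4c3)n2)cc1`, has not yet been measured in this assay. It differs from compound 2 in one place: formyl in place of ethyl on an aromatic carbon. Neither measured compound carries a formyl group at any position, and compound 1 and compound 2 differ from each other in more than one place. Their two values thus give no guide to what this single change does. Without such a guide, the step expected in this assay is a number 5.2 percentage points lower from compound 2 to compound 3 (within the scatter), a small step with no clear direction and within the scatter. Compound 3 is expected to give about 45% in this assay, within a range from 25% to 65%.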

Compound 3, a percentage reported as inhibition, at one concentration (the size of the read-out at that concentration, not a potency): 46.9%
Compound 3: the middle estimate sits 1.9 percentage points below what was measured; the range from low to high includes it.
By their numbers in this assay, from the lowest: compounds 1, 3 and 2 (each within the scatter of the next, the first and the last beyond it).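

In this assay, among the compounds shown here, the change from 4-ethylphenyl to 4-formylphenyl gives the first step that can be read for a single change: a number 3.3 percentage points lower from compound 2 to compound 3 (within the scatter) on this pair. At this position, on an aromatic carbon para to a large group, ethyl with no hydrogen-bond acceptor and formyl with one hydrogen-bond acceptor and a double bond outside the aromatic rings give numbers that cannot be told apart at the one concentration tested, so this swap shows no clear gain or loss on this read-out. No measurement at hand explains this outcome or says what each group does here.

Still open, as far as these compounds go, is whether any other group at this position would move the number beyond the scatter, for example an amine, a carboxylic acid or a longer chain such as butyl in place of the ethyl. Also open, from the compounds shown here alone, is what the group on the other side of the shared core contributes by itself, as compound 1 and compound 2 differ in more than one place and their values cannot separate the two changes.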